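This account rests on a few compounds, and the source may have more. Where it says the series, first, only, none or still open, it means among the compounds named here.

Of the compounds shown here, three have been measured so far in a functional assay on HCT-116 cells (Homo sapiens) for antiproliferative activity, read by MTT assay, with a stated time of 72 h (on this read-out lower numbers stand for stronger inhibition and higher numbers for weaker inhibition), as follows.

Compound 1 `O=C(CCc1cccc2c1B(O)OC2)Nc1cccc(I)c1` gives 2300 nM
Compound 2 `COc1cc(OC)cc(-c2cccc(NC(=O)CCc3cccc4c3B(O)OC4)c2)c1` gives 53 nM
Compound 3 `CC(=O)c1cccc(-c2cccc(NC(=O)CCc3cccc4c3B(O)OC4)c2)c1` gives 86 nM

Compound 2 cannot be separated from compound 3, as a 1.6-fold higher number from compound 2 to compound 3 (0.21 log units; within the scatter) shows, and both stand well clear of compound 1. Putting 3,5-dimethoxyphenyl in place of iodo gave a 43-fold lower number from compound 1 to compound 2 (1.64 log units; beyond the scatter) and putting 3-acetylphenyl there gave a 27-fold lower number from compound 1 to compound 3 (1.43 log units; beyond the scatter) as large steps.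

Compound 4 `COc1cc(OC)cc(-c2cccc(NC(=O)CCc3ccc4c(c3)B(O)OC4)c2)c1` differs from compound 2 by a group of 10 heavy atoms (7 carbon, 1 boron, 2 oxygen; one five-membered non-aromatic ring with 2 hetero atoms, one six-membered aromatic ring of carbon only) in place of a group of 10 heavy atoms (7 carbon, 1 boron, 2 oxygen; one five-membered non-aromatic ring with 2 hetero atoms, one six-membered aromatic ring of carbon only), on a saturated chain carbon, two bonds along the chain from a carbonyl carbon and the two have the same atoms, joined differently. All three measured steps change the group on an aromatic carbon, so none of them gives the size of this change directly. Among the compounds with values here, they show only that numbers in this assay can move widely within this set. With no direct guide, a moderate rise in the number is expected, beyond the scatter but uncertain in size. The expected change is a 4.7-fold higher number from compound 2 to compound 4 (0.67 log units; beyond the scatter) on this estimate. Compound 4 is estimated at 250 nM with an expected range from 60 nM to 1500 nM as its likely span.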

Compound 4, half-maximal inhibitory concentration: 3700 nM
Compound 4: middle estimate off by 15-fold (1.17 log units), on the low side, and the stated range ends below it.
By their numbers in this assay, from the lowest: compounds 2 and 3 (each within the scatter of the next); then compounds 1 and 4 (each within the scatter of the next).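

In this assay, within the data shown here, the earlier steps all changed the group on an aromatic carbon, and this is the first change on a saturated chain carbon, two bonds along the chain from a carbonyl carbon: the same atoms, joined differently, give a 70-fold higher number from compound 2 to compound 4 (1.84 log units; beyond the scatter). No atom is gained or lost and the counted donors and acceptors stay equal, yet the step is large, so the way these atoms are joined matters on its own, and the 3,5-dimethoxyphenyl group does not keep the number low by itself. Nothing measured here accounts for the size of this step.

Among these compounds, compound 4 is the only compound with this joining, so it remains open whether the same rise would appear with 3-acetylphenyl or iodo on the aromatic carbon. Also open, on these data alone, is how the number would respond to a longer chain, or to a carboxylic acid in place of the whole group.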